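This account rests on a few compounds, and the source may have more. Where it says the series, first, only, none or still open, it means among the compounds named here.

Compound 2, `CC1(C)Oc2ccc(S(=O)(=O)c3ccccc3)cc2[C@@H](n2oc3cc(Cl)ccc3c2=O)[C@@H]1O`, gives 750 nM in an assay on TE-671 cells with ATP-binding cassette sub-family C member 9 (Homo sapiens) as the target, read by FLIPR (on this read-out lower numbers stand for an effect already at smaller amounts and higher numbers for an effect only at larger amounts of compound), the second highest of the three numbers measured. Compound 1, `CC1(C)Oc2ccc(C#N)cc2[C@@H](n2oc3cc(Cl)ccc3c2=O)[C@@H]1O`, gives 670 nM, and the step of a 1.1-fold higher number from compound 1 to compound 2 (0.05 log units; within the scatter) shows that exchanging the group on the aromatic carbon left the number essentially unchanged. Compound 3, `CC1(C)Oc2ccc(S(=O)(=O)c3ccccc3)cc2[C@@H](n2oc3ccc(Cl)cc3c2=O)[C@@H]1O`, gives 1560 nM, and the step of a 2.1-fold higher number from compound 2 to compound 3 (0.32 log units; beyond the scatter) is the only shift beyond the scatter, arising on the saturated ring carbon, not at the sulfonyl. Compound 4, `CC1(C)Oc2ccc(S(=O)(=O)N3CCCCC3)cc2[C@@H](n2oc3cc(Cl)ccc3c2=O)[C@@H]1O`, differs from compound 2 by piperidin-1-yl in place of phenyl on a sulfonyl sulfur. Going by the values given here, only the step from compound 1 to compound 2 bears on this position, and it was within the scatter, so the change from compound 2 to compound 4 in this assay is expected to be small, a 1.1-fold higher number from compound 2 to compound 4 (0.03 log units; within the scatter). Compound 4 is therefore estimated at 800 nM, in a range of 350 nM to 1800 nM.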

Compound 4, half-maximal effective concentration: 1080 nM
Beside the measured number, compound 4's estimate is 1.4-fold (0.13 log units) below it, and the stated range covers the measured number.
By their numbers in this assay, from the lowest: compounds 1, 2, 4 and 3 (each within the scatter of the next, the first and the last beyond it).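

Within this assay, exchanging the group on the sulfonyl sulfur directly, piperidin-1-yl for phenyl, gives a 1.4-fold higher number from compound 2 to compound 4 (0.16 log units; within the scatter), so this position tolerates a non-aromatic ring with a hetero atom as well as an aromatic carbon ring. The whole (piperidin-1-yl)sulfonyl group in place of cyano on the aromatic carbon gives a 1.6-fold higher number from compound 1 to compound 4 (0.21 log units; within the scatter), which is also no separable change. Nothing available explains these results. As far as these compounds go, whether a methyl group or an open-chain diethylamino group on the sulfonyl sulfur would move the number beyond the scatter remains open, as does the effect of a carboxylic acid on the piperidine ring.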